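Fluoro for hydrogen on the pyrrole-side aryl of compound 3

A few compounds are considered here, and "the series" means these few. Any claim that something is new, unique, unknown or untested is made for them only; others in the source may bear on it.

Measured compounds:
compound 1, `CC(=O)c1cc(-c2ccc(F)cc2)cc2cc(-c3ccc(F)cc3)[nH]c12`, 90.1%
compound 2, `COc1ccc(-c2cc(C(C)=O)c3[nH]c(-c4ccc(F)cc4)cc3c2)cc1`, 74.5%
compound 3, `CC(=O)c1cc(/C=C/c2ccccc2)cc2cc(-c3ccccc3)[nH]c12`, 99.1%

All three were tested in a functional assay on HeLa cells (Homo sapiens) for cytotoxicity, read by MTT assay, with a stated time of 2 days, tested at 0.1 uM; a higher number here means a weaker effect of the compound at the concentration tested, a lower number a stronger effect. Compound 3 has the highest of the three numbers; its nearest neighbour is compound 1, whose value lies within the scatter of it, while the value of compound 2 lies beyond the scatter below it.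

The step considered here leads to compound 4, `CC(=O)c1cc(/C=C/c2ccccc2)cc2cc(-c3ccc(F)cc3)[nH]c12`. The difference is fluoro in place of hydrogen on an aromatic carbon; one bond further out it reads phenyl to 4-fluorophenyl.

Among the measured compounds shown here, no measured step carries this same change. For the measured compounds named here, the one step in hand, a number 15.6 percentage points lower from compound 1 to compound 2 (beyond the scatter), concerns methoxy in place of fluoro and is a modest one; it says nothing direct about fluoro replacing hydrogen. Compound 1, which carries fluoro on both aryl groups, and compound 3 differ in more than one place, so their two values alone are shown, and they lie within the scatter of each other.

Going by the values given here, with no bearing step, the expectation for compound 4 is a change of no more than the scatter, a number 4.1 percentage points lower from compound 3 to compound 4 (within the scatter), and compound 4 is estimated at 95%, ranging from 82% to 104%.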

Compound 4, a percentage reported as activity, at one concentration (the size of the read-out at that concentration, not a potency): 82.2%
Estimate against measurement, compound 4: 12.8 percentage points above; low and high end bracket the measured number.
By their numbers in this assay, from the lowest: compounds 2, 4, 1 and 3 (each within the scatter of the next, the first and the last beyond it).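

In this assay, phenyl to 4-fluorophenyl gives a number 16.9 percentage points lower from compound 3 to compound 4 (beyond the scatter), so a single fluoro on this aromatic carbon, para to a large group, is enough to register as a modest step in a series where this change had no reading before. Among the compounds shown here, with 4-fluorophenyl held on this ring, the other aryl site shows no separation: 2-phenylethenyl in place of 4-methoxyphenyl gives a number 7.7 percentage points higher from compound 2 to compound 4 (within the scatter), and 2-phenylethenyl in place of 4-fluorophenyl gives a number 7.9 percentage points lower from compound 1 to compound 4 (within the scatter), so among compounds 1, 2 and 4 only the step from compound 1 to compound 2 exceeds the scatter. Nothing at hand accounts for the step from hydrogen to fluoro.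

It remains open whether the same change gives a similar step when 4-fluorophenyl or 4-methoxyphenyl replaces 2-phenylethenyl, since only one fluoro-for-hydrogen pair is shown. Also open, as far as these compounds go, is how a chloro group, a methoxy group or an amine would read at this same carbon. Each reading comes from a single concentration. None of these steps can be taken as a difference in potency.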